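Naphthyl Ester Built on Analogues That All Sit at the Limit

A few compounds are considered here, and "the series" means these few. Any claim that something is new, unique, unknown or untested is made for them only; others in the source may bear on it.

Compound 3 `CC(C)c1cccc(OC(=O)c2cn(-c3ccccc3)nc2-c2ccncc2)c1` was tested in a functional assay on MDA-MB-231 cells (Homo sapiens) for cytotoxicity, read by MTT assay, with a stated time of 48 h; a higher number here means a weaker inhibitor, a lower number a stronger inhibitor. In this assay compound 3 gives only a limit of the assay, > 100000 nM, not a number. Compound 1 `CC(C)c1cccc(OC(=O)c2cn(-c3ccccc3)nc2-c2cccnc2)c1` likewise gives only a limit, > 100000 nM. Compound 2 `Cc1ccc(C(C)C)c(OC(=O)c2cn(-c3ccccc3)nc2-c2cccnc2)c1` also gives only a limit, > 100000 nM. The step that the two limits leave unreadable from compound 1 to compound 2 and the step that the two limits leave unreadable from compound 1 to compound 3 therefore cannot be sized, which is what the limit of > 100000 nM in this assay, at which 3 of the 3 values shown sit, records. Compound 4 `O=C(Oc1ccc2ccccc2c1)c1cn(-c2ccccc2)nc1-c1ccncc1` differs from compound 3 by naphthalen-2-yl in place of 3-isopropylphenyl on an oxygen next to a carbonyl group. No measured step bears on this change, so from what has been shown no direction beyond the scatter can be expected. Compound 4 is estimated at 100000 nM, within 30000 nM to 300000 nM, a step of a number no higher from compound 3 to compound 4 (the limit leaves the size open) that is expected to leave it at the limit as well.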

Compound 4, half-maximal inhibitory concentration: > 100000 nM
Compound 4 ended at the assay's limit; the forecaster's own chance of this, stated with the estimate: 80%; the middle value sits exactly at the limit.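

Compound 4, like compound 3, gives only a limit and not a number, so the change between them cannot be read as a step: the limit of > 100000 nM in this assay, at which 4 of the 4 values shown sit.

The compounds shown leave open which group on that oxygen, if any, would give a readable number in this assay.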